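The compounds below may be only part of what the source reports. "The series", "measured", "known", "first", "only" and "open" are said of these compounds alone.

Compound 1 `CC(C)S(=O)(=O)NC(=O)c1ccc(Nc2nc(NC3(c4ccc(Cl)cc4)CC3)nc(OCC(F)(F)F)n2)cc1` and compound 2 `CC(C)(C)CNCCS(=O)(=O)NC(=O)c1ccc(Nc2nc(NC3(c4ccc(Cl)cc4)CC3)nc(OCC(F)(F)F)n2)cc1` share one core and differ only in the group on the sulfonyl sulfur. In an ADME assay on microsomes from liver (Rattus norvegicus) for metabolic stability, with a stated time of 10 min (on this read-out higher numbers stand for a more stable compound and lower numbers for a less stable compound), compound 1 gives 96%, and compound 2 gives 90%. Among the measured compounds shown here, the single measured step, a number 6 percentage points lower from compound 1 to compound 2 (within the scatter), leaves compound 2 with the lower of the two numbers, but its distance to compound 1 stays inside the scatter, so no order between the two is read from it.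

Compound 3 `O=C(NS(=O)(=O)C1CC1)c1ccc(Nc2nc(NC3(c4ccc(Cl)cc4)CC3)nc(OCC(F)(F)F)n2)cc1` awaits measurement. Its change relative to compound 2 reads (cyclopropyl in place of 2-(neopentylamino)ethyl on a sulfonyl sulfur). For the measured compounds named here, the one measured step at this position, a number 6 percentage points lower from compound 1 to compound 2 (within the scatter), exchanged one sulfonyl substituent for another without moving the read-out beyond the scatter, and compound 1 already carries a small carbon group at this sulfur, as compound 3 will. On that basis no step beyond the scatter is expected in this assay for compound 3, in either direction.

Compound 3 is therefore estimated at 93%, with a range from 84% to 99%. The expected step of a number 3 percentage points higher from compound 2 to compound 3 (within the scatter) is one that should remain within the scatter.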

Compound 3, percent of the compound remaining: 85%
Estimate against measurement, compound 3: 8 percentage points above; low and high end bracket the measured number.
By their numbers in this assay, from the lowest: compounds 3, 2 and 1 (each within the scatter of the next, the first and the last beyond it).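

At the sulfonyl sulfur, this position now gives its first step beyond the scatter in this assay (a number 11 percentage points lower from compound 1 to compound 3 (beyond the scatter)), and this step comes from cyclopropyl in place of isopropyl, an exchange between two carbon-only groups. The exchange of cyclopropyl for the larger 2-(neopentylamino)ethyl chain, which also carries a nitrogen, stays inside the scatter (a number 5 percentage points lower from compound 2 to compound 3 (within the scatter)), so across these three compounds the size of the exchanged group does not track the size of the step, with compound 2 lying within the scatter of both compound 1 and compound 3. The series offers no measured information that explains why the read-out responds to the isopropyl-to-cyclopropyl exchange.

Open, going by these compounds, is whether the difference between compound 1 and compound 3 belongs to the three-membered ring itself or would also appear with a methyl, a straight propyl chain or a larger carbon ring such as cyclopentyl on the sulfonyl sulfur. Also open, on these data alone, is how a tertiary amine, a carboxylic acid or a longer chain ending in a morpholine would read at this position in the same assay, since the only nitrogen-bearing substituent here is the secondary amine of compound 2.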